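A few compounds are considered here, and "the series" means these few. Any claim that something is new, unique, unknown or untested is made for them only; others in the source may bear on it.

Measured compounds:
compound 1 `C#Cc1cn([C@@H]2O[C@H](CO)[C@@H](O)[C@H]2O)c2ncnc(OC)c12` — 8160 nM
compound 2 `COc1nc(N)nc2c1c(-c1ccccc1)cn2[C@@H]1O[C@H](CO)[C@@H](O)[C@H]1O` — > 20000 nM
compound 3 `CN(C)c1ncnc2c1c(-c1cc3ccccc3o1)cn2[C@@H]1O[C@H](CO)[C@@H](O)[C@H]1O` — > 20000 nM

In a functional assay on A549 cells (Homo sapiens), read by MTT assay, with a stated time of 72 h (a higher number here means a weaker inhibitor, a lower number a stronger inhibitor), compound 1 gives 8160 nM. Compound 2 returns only a limit in this assay, > 20000 nM. Compound 3 likewise returns only a limit, > 20000 nM. Among the compounds with values here, compound 3 therefore sits at the limit of > 20000 nM in this assay, at which 2 of the 3 values shown sit; it has no number of its own, only a floor, so no measured step starts from it, and its distance from compound 1 can be stated only as far as compound 1 has a number and compound 3 does not.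

Compound 4 `C#Cc1cn([C@@H]2O[C@H](CO)[C@@H](O)[C@H]2O)c2ncnc(N(C)C)c12` has not been measured. It differs from compound 3 in one place: ethynyl in place of 1-benzofuran-2-yl on an aromatic carbon. Compound 1 also carries the ethynyl group and gives 8160 nM, a number rather than a limit. On that basis compound 4 is expected to land in the same region as compound 1, under the floor at which the two limit values sit. The step of an at least 2.2-fold lower number from compound 3 to compound 4 (0.34 log units; beyond the scatter) is expected to be a gain of uncertain size. The estimate for compound 4 is 9000 nM, with a range from 3000 nM to 25000 nM, and a fair chance that only a limit is reported again.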

Compound 4, half-maximal inhibitory concentration: 390 nM
Estimate against measurement, compound 4: 23-fold (1.36 log units) above, and the stated range ends above it.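

At the aromatic carbon two ring bonds from the ring nitrogen, ethynyl in place of 1-benzofuran-2-yl gives an at least 51-fold lower number from compound 3 to compound 4 (1.70 log units; beyond the scatter) in this assay, so a dimethylamino compound now has a number in place of a limit. With ethynyl held constant, dimethylamino in place of methoxy on an aromatic carbon gives a 21-fold lower number from compound 1 to compound 4 (1.32 log units; beyond the scatter), so ethynyl alone does not set the level and this second change carries a large step of its own. Compound 3 returns only a limit, so the first step has a lower bound and no exact size: the limit of > 20000 nM in this assay, at which 2 of the 4 values shown sit.

Open, going by these compounds, is how an ethyl or a vinyl group would compare with ethynyl at this carbon. Also open, on these data alone, is how an unsubstituted amine or a methylamino group would compare with dimethylamino.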